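Swapping a Hydroxy for a Methyl on the Aryl Ring

The source may report more compounds than this note shows. Statements on the series, on what has been measured and on what is new or still open speak of the compounds shown alone.

Compound 1, `CCOc1ccccc1N1CCN(CCCNc2ncccc2C(=O)N(C)C)CC1`: in a functional assay on aorta for antagonist activity at Alpha-1D adrenergic receptor (Rattus norvegicus) (on this read-out lower numbers stand for tighter binding and higher numbers for weaker binding), compound 1 gives 7.94 nM.
Compound 2, `CN(C)C(=O)c1cccnc1NCCCN1CCN(c2ccccc2C(F)(F)F)CC1`: compound 2 gives 316 nM.
Compound 3, `COc1cc(O)ccc1N1CCN(CCCNc2ncccc2C(=O)N(C)C)CC1`: compound 3 gives 79.4 nM.

Among these three numbers, compound 3 holds the second highest. Its nearest neighbour is compound 2, reached by the step of a 4.0-fold lower number from compound 2 to compound 3 (0.60 log units; beyond the scatter). Its furthest is compound 1, reached by the step of a 10-fold higher number from compound 1 to compound 3 (1.00 log units; beyond the scatter).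

Compound 4, `COc1cc(C)ccc1N1CCN(CCCNc2ncccc2C(=O)N(C)C)CC1`, differs from compound 3 in one place: methyl in place of hydroxy on an aromatic carbon. Going by the values given here, no measured pair changes this group alone. The step of a 10-fold higher number from compound 1 to compound 3 (1.00 log units; beyond the scatter) brought in the hydroxy together with a change of the alkoxy group, and the step of a 40-fold higher number from compound 1 to compound 2 (1.60 log units; beyond the scatter) shows that a single change on this ring can shift the number a long way. Compound 4, like compound 1, carries no hydroxy on this ring, yet it keeps the methoxy of compound 3, so the data give only an indirect guide. A modest move toward lower numbers in this assay is expected: a 2.0-fold lower number from compound 3 to compound 4 (0.30 log units; within the scatter). Compound 4 is therefore estimated at 40 nM, within a range from 10 nM to 160 nM.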

Compound 4, dissociation constant: 39.8 nM
Beside the measured number, compound 4's estimate is 1.0-fold (0.00 log units) above it, and the stated range covers the measured number.
By their numbers in this assay, from the lowest: compound 1; then compounds 4 and 3 (each within the scatter of the next); then compound 2.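

Going by these compounds alone, putting a methyl in place of the hydroxy, para to a large group, isolates this position for the first time, and in this assay the result is a 2.0-fold lower number from compound 3 to compound 4 (0.30 log units; within the scatter), so losing the hydroxy's hydrogen-bond donor and acceptor produces no change beyond the scatter. The gaps to the other aryl groups remain without the hydroxy, with a 5.0-fold higher number from compound 1 to compound 4 (0.70 log units; beyond the scatter) and a 7.9-fold lower number from compound 2 to compound 4 (0.90 log units; beyond the scatter), so the hydroxy alone does not set compound 3 apart from compound 1. No supporting measurement is available to explain these numbers.

The compounds shown leave open how an amine or a carboxylic acid at this position would read. They also leave open how the methyl would read with an ethoxy in place of the methoxy.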